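Compound 2 and the tetrazole step

This account rests on a few compounds, and the source may have more. Where it says the series, first, only, none or still open, it means among the compounds named here.

compound 1 `CCS(=O)(=O)c1cccc(-c2nc3cccnc3n2C2CCCCC2)c1` gives 164 nM
compound 2 `COC(=O)c1ccc(-c2nc3cccnc3n2C2CCCC2)cc1` gives 350 nM
compound 3 `COc1ncc(-c2nc3cccnc3n2C2CCCC2)c(OC)n1` gives > 10000 nM as a limit of the assay

Within the data shown here, all three values come from a functional assay on MDA-MB-231 cells (Homo sapiens) for cytotoxicity, read by MTT assay, with a stated time of 24 h (on this read-out higher numbers stand for weaker inhibition and lower numbers for stronger inhibition), and are the only measurements available. Among the two actual numbers, compound 2 at 350 nM holds the higher place, and compound 1 at 164 nM lies lower by a margin just beyond the usual scatter. Compound 3 sits at a limit of the assay (> 10000 nM).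

The next compound, compound 4 `c1cnc2c(c1)nc(-c1ccc(-c3nnn[nH]3)cc1)n2C1CCCC1`, has not yet been measured. It carries 1H-tetrazol-5-yl in place of methoxycarbonyl on an aromatic carbon of a six-membered aromatic ring of carbon only, para to a large group (1H-tetrazol-5-yl in place of methoxycarbonyl on an aromatic carbon).

Among the measured compounds shown here, no two measured compounds differ in one place only, so this change has no direct precedent here, and any forecast remains uncertain. Starting from compound 2 at 350 nM in this assay, a step beyond the scatter towards a higher number, meaning weaker inhibition, is expected. The estimated step is a 4.3-fold higher number from compound 2 to compound 4 (0.63 log units; beyond the scatter) and it may prove smaller or larger. Compound 4 is expected at 1500 nM (estimated range 300 nM to 8000 nM).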

Compound 4, half-maximal inhibitory concentration: 765 nM
Beside the measured number, compound 4's estimate is 2.0-fold (0.29 log units) above it, and the stated range covers the measured number.
By their numbers in this assay, from the lowest: compound 1; then compound 2; then compound 4. At a limit, above all of these: compound 3.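

In this assay, 1H-tetrazol-5-yl in place of methoxycarbonyl on an aromatic carbon, para to a large group, gives a 2.2-fold higher number from compound 2 to compound 4 (0.34 log units; beyond the scatter). Among these compounds, this is the first change in the set that can be read in one place only, and it shows a modest loss of inhibition beyond the scatter when a five-membered aromatic ring with 4 hetero atoms and a hydrogen-bond donor replaces a group with no ring and no donor. The change leaves compound 4 with a measured number and not a limit, while compound 3 remains the only compound held at a limit: the limit of > 10000 nM in this assay, at which 1 of the 4 values shown sits.

This single step cannot separate the contribution of the ring from that of the donor, and it rests on one position of one core. It leaves open whether a carboxylic acid or an amine at this same place would stand nearer to compound 2 or to compound 4, and whether the same exchange would give a step of similar size on the core of compound 1.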